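This account rests on a few compounds, and the source may have more. Where it says the series, first, only, none or still open, it means among the compounds named here.

Measured so far:
compound 1 `O=C(Nc1ccccn1)c1c(O)c2cccnc2n(-c2ccccc2)c1=O` — 14.6%
compound 2 `COc1ccccc1NC(=O)c1c(O)c2cccnc2n(-c2ccccc2)c1=O` — -10.1%

Both numbers come from a functional assay on the whole organism for inhibition, with Rattus norvegicus as the target, read by cytopathic effect and paw edema, at a dose of 100 mg/kg by the oral route; on this read-out higher numbers stand for more inhibition at the one dose given (going by the name of the read-out) and lower numbers for less inhibition. Going by the values given here, compound 2 stands lowest of the two; its nearest neighbour is compound 1, which gives 14.6%, and the one measured step, a number 24.7 percentage points lower from compound 1 to compound 2 (beyond the scatter), runs downward beyond the scatter.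

Compound 3 `O=C(NCc1ccncc1)c1c(O)c2cccnc2n(-c2ccccc2)c1=O` is not yet measured. Relative to compound 2 it carries (pyridin-4-yl)methyl in place of 2-methoxyphenyl on an amide-type nitrogen.

Among the compounds with values here, only the step from compound 1 to compound 2 bears on this move. It took the amide-type nitrogen from pyridin-2-yl to 2-methoxyphenyl and cost a number 24.7 percentage points lower from compound 1 to compound 2 (beyond the scatter). Within the data shown here, compound 3 brings back a six-membered aromatic ring with 1 hetero atom and one hydrogen-bond acceptor, but as (pyridin-4-yl)methyl rather than pyridin-2-yl; no measured pair shows what that particular exchange does. The expectation in this assay is therefore a partial recovery toward compound 1, an upward step of about a number 15.1 percentage points higher from compound 2 to compound 3 (beyond the scatter) from compound 2, carried with wide uncertainty. Compound 3 is estimated at 5%, with a range from -15% to 25%.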

Compound 3, a percentage reported as inhibition, in the whole organism at one dose (the size of the read-out at that dose, not a potency): 15.4%
For compound 3 the middle estimate is 10.4 percentage points below the measured one; the measured number falls inside the stated range.
By their numbers in this assay, from the lowest: compound 2; then compounds 1 and 3 (each within the scatter of the next).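

In this assay, the amide-type nitrogen accepts a ring on a one-carbon link: (pyridin-4-yl)methyl in place of 2-methoxyphenyl gives a number 25.5 percentage points higher from compound 2 to compound 3 (beyond the scatter). Against pyridin-2-yl, the same group gives a number 0.8 percentage points higher from compound 1 to compound 3 (within the scatter), so the two pyridine-bearing groups cannot be told apart on this read-out, and only compound 2, with 2-methoxyphenyl, stands apart from the other two. No measurement on hand accounts for either step, and the link and the change of pyridine attachment arrive together in one exchange, so their separate contributions cannot be read.

Open, on these data alone, is whether plain phenyl or benzyl on the amide-type nitrogen would fall with compound 2 or with compound 1 and compound 3, which would show whether the pyridine ring nitrogen or the methoxy group sets the difference. Also open, as far as these compounds go, is how a longer chain, such as 2-(pyridin-4-yl)ethyl, or a dimethylaminoethyl group would read at this position, and this assay at its one oral dose gives the size of the effect rather than a potency.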